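Removing the anilide aryl group entirely from a triazole thioacetamide

This account rests on a few compounds, and the source may have more. Where it says the series, first, only, none or still open, it means among the compounds named here.

Compound 1, `Cc1ccc(NC(=O)CSc2nnc(-c3ccoc3C)n2Cc2ccco2)cc1`: in a functional assay on CHO cells for antagonist activity at Orexin/Hypocretin receptor type 1 (Homo sapiens), read by FLIPR and calcium flux (a higher number here means a weaker inhibitor, a lower number a stronger inhibitor), compound 1 gives > 15800 nM, which is a limit of the assay and not a number.
Compound 2, `COc1ccc(NC(=O)CSc2nnc(-c3ccoc3C)n2Cc2ccco2)cc1`: in this assay compound 2 gives > 15800 nM, likewise a limit of the assay.

Among the measured compounds shown here, compound 2 therefore stands at the limit of the assay, and the one measured step, a step that the two limits leave unreadable from compound 1 to compound 2, is unreadable because of the limit of > 15800 nM in this assay, at which 2 of the 2 values shown sit. Compound 3, `Cc1occc1-c1nnc(SCC(N)=O)n1Cc1ccco1`, differs from compound 2 by hydrogen in place of 4-methoxyphenyl on an amide-type nitrogen. For the measured compounds named here, the only measured step concerns a change on the aryl ring that compound 3 no longer carries, so it gives no readable size for the step to compound 3 in this assay. With both measured values at the limit, compound 3 is expected to remain at or beyond that limit; the estimated step that the limit leaves unreadable from compound 2 to compound 3 is not readable in either direction. For compound 3 the estimate in this assay is 30000 nM, with a range from 10000 nM to 100000 nM, most likely reported only as a limit.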

Compound 3, inhibition constant: > 15800 nM
Compound 3 ended at the assay's limit; the forecaster's own chance of this, stated with the estimate: 85%; the middle value does not contradict the limit.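

No step can be read among compound 1, compound 2 and compound 3, because all three stand at the same limit of the assay: the limit of > 15800 nM in this assay, at which 3 of the 3 values shown sit.

The compounds shown leave open how strongly any of them acts in this assay and whether 4-methylphenyl, 4-methoxyphenyl or hydrogen on the amide-type nitrogen makes any difference.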